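This account rests on a few compounds, and the source may have more. Where it says the series, first, only, none or still open, it means among the compounds named here.

Measured in a functional assay on HeLa cells (Homo sapiens) for inhibition, read by CCK-8 assay, with a stated time of 48 h; a lower number here means a stronger inhibitor, a higher number a weaker inhibitor:
- compound 1 `COc1cc(-c2ccnc3cc(-c4ccc(C(F)(F)F)cc4)nn23)cc(OC)c1OC`: 1840 nM
- compound 2 `C=Cc1ccc(-c2cc3nccc(-c4cc(OC)c(OC)c(OC)c4)n3n2)cc1`: 882 nM
- compound 3 `COc1cc(-c2ccnc3cc(-c4ccc(C(C)=O)cc4)nn23)cc(OC)c1OC`: 1810 nM

Compound 3 sits together with compound 1 at the high end of these three numbers, as a 1.0-fold lower number from compound 1 to compound 3 (0.01 log units; within the scatter) shows. Compound 2 has the lowest number, and the series shows a 2.1-fold higher number from compound 2 to compound 3 (0.31 log units; beyond the scatter).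

The next compound is compound 4 `COc1cc(-c2ccnc3cc(-c4ccc(-c5cnn(C)c5)cc4)nn23)cc(OC)c1OC`. It has 1-methyl-1H-pyrazol-4-yl in place of acetyl on an aromatic carbon of a six-membered aromatic ring of carbon only, para to a large group: 1-methyl-1H-pyrazol-4-yl in place of acetyl on an aromatic carbon.

For the measured compounds named here, three measured steps bear on this change, since all of them swap the group at this same place. The largest are modest, namely a 2.1-fold lower number from compound 1 to compound 2 (0.32 log units; beyond the scatter) and the step to compound 3 from compound 2 given above, while trifluoromethyl and acetyl differ by a 1.0-fold lower number from compound 1 to compound 3 (0.01 log units; within the scatter). Going by the values given here, none of the measured compounds carries a ring at this place, so the data cannot show how the entering group will behave, and the range has to stay wide.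

In this assay, a step no larger than these is expected, most likely within the scatter and leaning slightly towards a lower number. The estimated step is a 1.5-fold lower number from compound 3 to compound 4 (0.18 log units; within the scatter). For compound 4 the expected value is 1200 nM, with an estimated range from 350 nM to 3500 nM.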

Compound 4, half-maximal inhibitory concentration: 1830 nM
Beside the measured number, compound 4's estimate is 1.5-fold (0.18 log units) below it, within the range that was stated.
By their numbers in this assay, from the lowest: compound 2; then compounds 3, 4 and 1 (each within the scatter of the next).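

The first ring at this place, 1-methyl-1H-pyrazol-4-yl on the six-membered aromatic ring, brings no separation from the non-ring groups in this assay: replacing acetyl gives a 1.0-fold higher number from compound 3 to compound 4 (0.00 log units; within the scatter), and replacing trifluoromethyl gives a 1.0-fold lower number from compound 1 to compound 4 (0.00 log units; within the scatter), so compounds 1, 3 and 4 cannot be told apart. Vinyl is now the only group of the four that stands apart, since replacing it gives a 2.1-fold higher number from compound 2 to compound 4 (0.32 log units; beyond the scatter), and the position therefore accepts a ring and two quite different non-ring groups with no difference beyond the scatter among them. Nothing available explains why compound 2 differs from the other three.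

As far as these compounds go, it remains open whether an amine, a carboxylic acid or a longer chain at this place would stay level with compounds 1, 3 and 4, move towards compound 2, or go beyond both. From the compounds shown here alone, all four compounds also share one core and carry their changing group at this one place, so whether the gap between vinyl and the other groups would hold on a different core is unknown.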